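Removing one amino group from a diaminopyrimidine nitrile

The source may hold more compounds than are shown below. What is called first, only, known or untested is meant among the compounds shown, and "the series" means these compounds.

Measured compounds:
- compound 1 `C[C@H](Nc1nc(N)nc(N)c1C#N)c1cc2ccc(F)cn2c(=O)c1-c1ccc(F)cc1`: 84%
- compound 2 `C[C@H](Nc1nc(N)nc(N)c1C#N)c1cc(=O)n2cc(F)ccc2c1-c1ccccc1`: "not determined" (no result reported)

Compound 1 was examined in an ADME assay on microsomes from liver (Mus musculus), read by LC-MS, using NADPH, with a stated time of 30 min, tested at 1 uM (a higher number here means that more of the compound is left, a lower number that less of the compound is left), and gives 84%, so most of it survives the incubation. Compound 2, which shares the aminopyrimidine nitrile side chain but carries a different arrangement of the fluorine and of the carbonyl on its core and a plain phenyl ring in place of the fluorophenyl ring, gives "not determined" (no result reported) in this assay, that is, no number at all. Compound 2 therefore stands nowhere on the scale yet; the only measured point in this series is compound 1.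

Compound 3 `C[C@H](Nc1ncnc(N)c1C#N)c1cc(=O)n2cc(F)ccc2c1-c1ccccc1` is the next compound. It differs from compound 2 in a single place: hydrogen in place of amino on an aromatic carbon, in words, hydrogen in place of amino on an aromatic carbon. Among the measured compounds shown here, no step between measured compounds describes this change, and compound 2 itself has no value, so the direction and size of the effect are open; nothing in the data points to a shift beyond the usual scatter. Taking the result of compound 1, 84%, as the only anchor, compound 3 is expected to give about 75% remaining, within a range from 45% to 95%.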

Compound 3, percent of the compound remaining: 69%
Estimate against measurement, compound 3: 6 percentage points above; the measured number falls inside the stated range.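

In this assay, among the compounds shown here, compound 3 gives 69% and compound 2 gives "not determined" (no result reported) and so no step between these two compounds can be read. The compounds shown leave open what replacing the amino group with hydrogen does to the percent of compound remaining. Nothing in the available evidence bears on this result.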